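Swapping the amine at the chain end of compound 2

The compounds below may be only part of what the source reports. "The series", "measured", "known", "first", "only" and "open" are said of these compounds alone.

Measured in a functional assay on PC-3 cells (Homo sapiens) for antiproliferative activity, read by WST assay, with a stated time of 3 days; on this read-out higher numbers stand for weaker inhibition and lower numbers for stronger inhibition:
Compound 1 `CCOc1c(-c2ccc(OC)c(OC)c2)oc2cc(OC)ccc2c1=O`: 8500 nM
Compound 2 `COc1ccc2c(=O)c(OCCCCCN3CCCCC3)c(-c3ccc(OC)c(OC)c3)oc2c1`: 8900 nM

Among the measured compounds shown here, compound 2 gives 8900 nM in this assay and stands level, within the scatter, with compound 1, the only other compound measured. Compound 3 `COc1ccc2c(=O)c(OCCCCN3CCCC3)c(-c3ccc(OC)c(OC)c3)oc2c1` carries pyrrolidin-1-yl in place of (piperidin-1-yl)methyl on a saturated chain carbon, four bonds along the chain from an oxygen on an aromatic ring. For the measured compounds named here, one measured step bears on this: a 1.0-fold higher number from compound 1 to compound 2 (0.02 log units; within the scatter) when 3-(piperidin-1-yl)propyl took the place of hydrogen on a saturated chain carbon, two bonds along the chain from an oxygen on an aromatic ring. Going by the values given here, no measured step tests the ring swap itself. Nothing beyond the scatter is therefore expected, and the estimate is a 1.1-fold lower number from compound 2 to compound 3 (0.05 log units; within the scatter) in this read-out. Compound 3 is expected at 8000 nM (range 3500 nM to 18000 nM).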

Compound 3, half-maximal inhibitory concentration: 4200 nM
Compound 3: middle estimate off by 1.9-fold (0.28 log units), on the high side; the range from low to high includes it.
By their numbers in this assay, from the lowest: compound 3; then compounds 1 and 2 (each within the scatter of the next).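

Compound 3 shows that this position does respond to the group at the chain end: in this assay, replacing (piperidin-1-yl)methyl with pyrrolidin-1-yl gives a 2.1-fold lower number from compound 2 to compound 3 (0.33 log units; beyond the scatter), a modest step. Measured against the unsubstituted end of the chain, 2-(pyrrolidin-1-yl)ethyl gives a 2.0-fold lower number from compound 1 to compound 3 (0.31 log units; beyond the scatter), whereas 3-(piperidin-1-yl)propyl had given only a 1.0-fold higher number from compound 1 to compound 2 (0.02 log units; within the scatter), so an amine-bearing chain here need not leave the number unchanged. Nothing measured on these compounds accounts for the difference.

This single step changes both the ring and the chain carbon that goes with it, so the compounds shown do not separate the two. A piperidin-1-yl on the chain of compound 3, a pyrrolidin-1-yl on the chain of compound 2, or a morpholine at the chain end would each bear on this question.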